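A few compounds are considered here, and "the series" means these few. Any claim that something is new, unique, unknown or untested is made for them only; others in the source may bear on it.

Measured in a functional assay on IMR-32 cells (Homo sapiens) for inhibition, read by sulforhodamine B assay, with a stated time of 48 h, tested at 100 uM; on this read-out lower numbers stand for less inhibition of growth and higher numbers for more inhibition of growth at the one concentration tested: compound 1 `O=c1c(C2N=C(c3ccccc3)SS2)coc2ccc(Cl)cc12` gives 92%; compound 2 `O=c1c(C(=S)Nc2ccccc2)coc2cc(Cl)c(Cl)cc12` gives 18%.

Compound 1 holds the higher of these two numbers, and compound 2 sits a long way below it, beyond the scatter. Compound 3 `O=c1c(C2N=C(c3ccccc3)SS2)coc2ccccc12` has not yet been measured in this assay. It differs from compound 1 by hydrogen in place of chloro on an aromatic carbon. Among the compounds with values here, no pair of measured compounds shows this change, so nothing directly anchors it. The step of a number 10 percentage points lower from compound 1 to compound 3 (within the scatter) is expected to be small and downward, likely not beyond the scatter. Compound 3 is therefore estimated at 82%, within 55% to 96%.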

Compound 3, percent growth inhibition at one concentration: 82%
The estimate for compound 3 equals the measured number at the digits printed, and the stated range covers the measured number.
By their numbers in this assay, from the lowest: compound 2; then compounds 3 and 1 (each within the scatter of the next).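

In this assay, the first pair differing in one place gives a number 10 percentage points lower from compound 1 to compound 3 (within the scatter), with hydrogen in place of chloro on an aromatic carbon. At this position, meta to a fused ring and para to a fused ring, the chloro is therefore not required for the high growth inhibition at the one concentration tested. No measurement at hand accounts for this step.

The compounds shown leave open how an amine, a methoxy group or a carboxylic acid at this position would read. They also leave open whether other positions on this ring tolerate change equally well.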